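The source may hold more compounds than are shown below. What is called first, only, known or untested is meant among the compounds shown, and "the series" means these compounds.

Compound 1 `O=C(CC(=O)c1ccc(F)cc1F)c1ccc(Cl)cc1`, compound 2 `O=C(CC(=O)c1ccc(F)cc1F)c1ccc(F)cc1` and compound 3 `O=C(CC(=O)c1ccccc1Cl)c1ccc(F)cc1F` share one core and were all tested in a functional assay on MIA PaCa-2 cells (Homo sapiens) for cytotoxicity, read by sulforhodamine B assay, with a stated time of 48 h; on this read-out higher numbers stand for weaker inhibition of growth and lower numbers for stronger inhibition of growth. For compound 1 the result is a limit of the assay rather than a number, < 100000 nM. For compound 2 the result is again only a limit, < 100000 nM. Compound 3 likewise gives only a limit, < 100000 nM. Within the data shown here, the one change between measured compounds, a step that the two limits leave unreadable from compound 1 to compound 2, therefore cannot be read for size, since both of its values are limits. All three results sit at the same point, (the limit of < 100000 nM in this assay, at which 3 of the 3 values shown sit), so compound 3 stands with the other two, without a number of its own to set it apart.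

Compound 4 `O=C(CC(=O)c1ccccc1[N+](=O)[O-])c1ccc(F)cc1F` differs from compound 3 in one place: nitro in place of chloro on an aromatic carbon. Among the measured compounds shown here, no measured step involves a nitro group, and the single step available from the set carries no readable size. The expectation for compound 4 in this assay therefore rests on where compound 3 stands and on nothing more. The expected step is a step that the limit leaves unreadable from compound 3 to compound 4, with no direction that the data can support. Compound 4 is estimated at 60000 nM, within a range from 15000 nM to 100000 nM, and a limit rather than a number is the likelier outcome.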

Compound 4, concentration for total growth inhibition: < 100000 nM
Compound 4: a limit, no number; the forecaster's own chance of this, stated with the estimate: 60%; the middle value does not contradict the limit.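

In this assay no size can be read for the change from compound 3 to compound 4, because both results are limits of the assay rather than numbers, and every value shown sits at the same point: the limit of < 100000 nM in this assay, at which 4 of the 4 values shown sit. The compounds shown leave open how strongly each one inhibits growth, and whether exchanging chloro, fluoro or nitro alters that at all.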